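The source may hold more compounds than are shown below. What is called first, only, known or untested is meant among the compounds shown, and "the series" means these compounds.

Compound 1 `O=C(Nc1cccc(-n2cc(-c3ccncc3)c(-c3cc(O)cc(Cl)c3)n2)c1)Nc1ccc(Cl)c(C(F)(F)F)c1` gives 94% in a functional assay on MDA-MB-468 cells (Homo sapiens) for inhibition, read by sulforhodamine B assay, with a stated time of 48 h, tested at 0.1 uM; a higher number here means a weaker effect of the compound at the concentration tested, a lower number a stronger effect. Compound 2 `COc1cc(Cl)cc(-c2nn(-c3cccc(NC(=O)Nc4ccc(Cl)c(C(F)(F)F)c4)c3)cc2-c2ccncc2)c1` gives 91% in this assay. Compound 3 `COc1cc(Cl)cc(-c2nn(-c3cccc(NC(=O)Nc4cc(C(F)(F)F)cc(C(F)(F)F)c4)c3)cc2-c2ccncc2)c1` gives 89% in this assay.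

Compound 2 stands second highest of the three numbers; compound 3 is nearest, and compound 1 furthest, both within the scatter of compound 2. Among the compounds with values here, the one single-change step, a number 3 percentage points lower from compound 1 to compound 2 (within the scatter), was within the scatter and concerns methyl in place of hydrogen on an oxygen, not the part changed here. Compound 4 `COc1cc(Cl)cc(-c2nn(-c3cccc(NC(=O)c4cccc(C(F)(F)F)c4)c3)cc2-c2ccncc2)c1` differs from compound 2 by 3-(trifluoromethyl)phenyl in place of (4-chloro-3-(trifluoromethyl)phenyl)amino on a carbonyl carbon. Within the data shown here, no measured step bears on this change, so nothing beyond the scatter is expected, and compound 4 is estimated at 92%, between 78% and 100%, a step of a number 1 percentage points higher from compound 2 to compound 4 (within the scatter) expected.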

Compound 4, a percentage reported as activity, at one concentration (the size of the read-out at that concentration, not a potency): 85%
For compound 4 the middle estimate is 7 percentage points above the measured one; low and high end bracket the measured number.
By their numbers in this assay, from the lowest: compounds 4, 3, 2 and 1 (each within the scatter of the next).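

Within the data shown here, the step of a number 6 percentage points lower from compound 2 to compound 4 (within the scatter) in this assay is the first reading at this place, on a carbonyl carbon whose other neighbour is an amide-type nitrogen. The change removes the nitrogen with its hydrogen-bond donor and the chlorine, yet the read-out stays within the scatter. No measurement on hand accounts for this step.

With both features changing together, the compounds shown leave open what the chlorine and the nitrogen each contribute alone. They also leave open how a carboxylic acid or a morpholine at this place would read.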